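Compound 3: a further methoxy on an inactive series

The compounds below may be only part of what the source reports. "The series", "measured", "known", "first", "only" and "open" are said of these compounds alone.

In a functional assay on CNE-2 cells (Homo sapiens) for antiproliferative activity, read by sulforhodamine B assay, with a stated time of 48 h (on this read-out higher numbers stand for weaker inhibition and lower numbers for stronger inhibition), compound 1 (`COc1ccc(CNC(=O)c2ccccc2-c2ccc(F)cc2)cc1`) gives > 50000 nM, a limit. Compound 2 (`COc1ccc(CNC(=O)c2ccccc2-c2ccc(F)cc2)cc1OC`) gives > 50000 nM, also a limit, so it has no exact position. Compound 3 (`COc1cc(CNC(=O)c2ccccc2-c2ccc(F)cc2)cc(OC)c1OC`) has methoxy in place of hydrogen on an aromatic carbon. Among the compounds with values here, the same kind of change gave the only measured step, a step that the two limits leave unreadable from compound 1 to compound 2, and the limit of > 50000 nM in this assay, at which 2 of the 2 values shown sit, is the sole evidence. No step beyond the scatter is therefore expected in this assay, and no direction can be assigned. The expected step is an at least 1.1-fold lower number from compound 2 to compound 3 (0.04 log units; that floor lies within the scatter). Compound 3 is estimated at 45000 nM, within an expected range of 10000 nM to 100000 nM.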

Compound 3, half-maximal inhibitory concentration: > 50000 nM
Compound 3: no number, only a limit; the forecaster's own chance of this, stated with the estimate: 75%; middle value at least 1.1-fold (0.04 log units) from the limit.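

Within the data shown here, compound 3 gives > 50000 nM, a limit, so no step from compound 2 to compound 3 can be read. The compounds shown leave open whether the added methoxy groups change inhibition at all, since compounds 1, 2 and 3 have no exact values.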